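The source may hold more compounds than are shown below. What is called first, only, known or untested is meant among the compounds shown, and "the series" means these compounds.

Working notes on the series. For the measured compounds named here, in an ADME assay on the whole organism (Rattus norvegicus, strain Sprague-Dawley) for pharmacokinetics, with a stated time of 6 h, at a dose of 10 mg/kg by the oral route (a lower number here means less compound in the circulation, a higher number more compound in the circulation at the dose given), compound 3 `Cc1cn2nc(-c3cc(=O)n4cc(N5CCN(C)CC5)ccc4n3)cc2c(C)n1` gives 2100 ng.h/mL, the highest number so far, and compound 1 `Cc1cn2cc(-c3cc4ccc(N5CCN(C)[C@@H](C)C5)cc4oc3=O)nc2c(C)n1` gives 260 ng.h/mL. Compound 2 `Cc1cn2nc(-c3cc(=O)n4cc(N5CCN(C)CC5)ccc4n3)cc2cn1` reads < 10 ng.h/mL, which is a limit and not a number. Compound 4 `Cc1cn2nc(-c3cc(=O)n4cc(N5CCNCC5)ccc4n3)cc2c(C)n1` differs from compound 3 by hydrogen in place of methyl on an amine nitrogen in a ring, so that 4-methylpiperazin-1-yl becomes piperazin-1-yl.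

Going by the values given here, the one measured step, methyl in place of hydrogen on an aromatic carbon, gave an at least 210-fold higher number from compound 2 to compound 3 (2.32 log units; beyond the scatter). This step is large, but it lies elsewhere in the molecule, so its size does not carry over. Among the compounds with values here, no measured step touches the amine nitrogen, and the three measured compounds all carry methyl there. The step does show that a single methyl can move this assay far, so the range is kept wide. A moderately lower number is expected, with a 2.6-fold lower number from compound 3 to compound 4 (0.42 log units; beyond the scatter) as the estimated step. For compound 4 the expected value is 800 ng.h/mL, with an estimated range of 150 ng.h/mL to 3000 ng.h/mL.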

Compound 4, area under the concentration-time curve: 380 ng.h/mL
Compound 4: the middle estimate sits 2.1-fold (0.32 log units) above what was measured; the measured number falls inside the stated range.
By their numbers in this assay, from the lowest: compounds 1 and 4 (each within the scatter of the next); then compound 3. At a limit, below all of these: compound 2.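

In this assay the amine nitrogen in the ring now has a measured step of its own: a 5.5-fold lower number from compound 3 to compound 4 (0.74 log units; beyond the scatter). This step is beyond the scatter, so the methyl on this nitrogen counts for the read-out, though the change is smaller than the one on the aromatic carbon, an at least 210-fold higher number from compound 2 to compound 3 (2.32 log units; beyond the scatter). Nothing at hand bears on the cause of the step at the amine nitrogen.

The compounds shown leave open how an ethyl or an acetyl group on the same nitrogen would read, so only hydrogen and methyl can be compared there. Going by these compounds, whether the same change carries over to the core of compound 1, which also has a second methyl on its ring, also stays open.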